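The source may report more compounds than this note shows. Statements on the series, on what has been measured and on what is new or still open speak of the compounds shown alone.

Measured in an ADME assay on microsomes from liver (Mus musculus) for metabolic stability, using NADPH, with a stated time of 10 min; on this read-out higher numbers stand for a more stable compound and lower numbers for a less stable compound:
compound 1 `NCCCCN(C[C@@H]1Cc2ncccc2CN1)[C@H]1CCCc2cccnc21`: 75%
compound 2 `NCCCCN(C[C@@H]1Cc2cccnc2CN1)[C@H]1CCCc2cccnc21`: 25%
compound 3 `NC/C=C\CN(C[C@H]1Cc2ncccc2CN1)[C@H]1CCCc2cccnc21`: 37%

Compound 3, at 37%, stands in the middle of these three numbers. It lies above compound 2, which gives 25%, and that gap is beyond the usual scatter of repeated measurements. The gap up to compound 1, which gives 75%, is larger and also beyond the scatter.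

The next compound to be tested is compound 4 `NC(=O)NC/C=C/CN(C[C@H]1Cc2ncccc2CN1)[C@H]1CCCc2cccnc21`. Compared with compound 3, the 3-aminoprop-1-en-1-yl group leaves and a larger group without a ring takes its place, on a saturated chain carbon bound to an amine nitrogen: a group of 7 heavy atoms (4 carbon, 2 nitrogen, 1 oxygen; no ring) in place of a group of 4 heavy atoms (3 carbon, 1 nitrogen; no ring), on a saturated chain carbon bound to an amine nitrogen.

Within the data shown here, no two measured compounds differ in only one place, so the data give no direct measure of what this kind of change does in this assay. Among the measured compounds shown here, the only guide is the spread of the set. Compound 1, at 75%, shows that numbers well above that of compound 3 occur among these structures. A moderate rise therefore seems more likely than a fall, but with little certainty, and a result within the scatter would be no surprise. The expected change is a number 13 percentage points higher from compound 3 to compound 4 (beyond the scatter). For compound 4 the estimate is 50%, with an expected range from 25% to 76%.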

Compound 4, percent of the compound remaining: 19%
For compound 4 the middle estimate is 31 percentage points above the measured one; measured number outside the range, below it.
By their numbers in this assay, from the lowest: compounds 4 and 2 (each within the scatter of the next); then compound 3; then compound 1.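

In this assay the exchange gives a number 18 percentage points lower from compound 3 to compound 4 (beyond the scatter) and so shows that the group on this saturated chain carbon bound to an amine nitrogen has a bearing on how much compound remains. Replacing 3-aminoprop-1-en-1-yl with the larger group of 7 heavy atoms, which brings a second nitrogen, an oxygen and a second double bond outside aromatic rings, goes with less compound remaining rather than more, though the step is only modest in size. No measurement here explains this fall, and this one step cannot separate the added atoms from the different arrangement around the chain's double bond in the two structures.

From the compounds shown here alone, it remains open whether a smaller group at this place, such as aminomethyl, or a chain ending in a carboxylic acid would leave more compound remaining. Going by these compounds, it is also open whether the same exchange would give a step of similar size on the core of compound 2, or with the double bond arranged the same way in both chains.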